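A few compounds are considered here, and "the series" means these few. Any claim that something is new, unique, unknown or untested is made for them only; others in the source may bear on it.

Compound 1 `CC(=O)Nc1ccc2oc(-c3ccc(F)cc3)cc(=O)c2c1` is the reference point of this small series. In an ADME assay on THP-1 cells (Homo sapiens) for cytotoxicity, read by flow cytometry and propidium iodide staining, with a stated time of 72 h (a lower number here means a stronger inhibitor, a higher number a weaker inhibitor), compound 1 gives 22000 nM. Compound 2 `CC(=O)Nc1ccc2oc(-c3ccc(C(F)(F)F)cc3)cc(=O)c2c1` carries the change trifluoromethyl in place of fluoro on an aromatic carbon and in this assay compound 2 gives 10000 nM, so that the step is a 2.2-fold lower number from compound 1 to compound 2 (0.34 log units; beyond the scatter).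

Compound 3 `CC(=O)Nc1ccc2oc(-c3cccc(F)c3)c(O)c(=O)c2c1` has a different core; how the core of compound 3 differs from the core of compound 1 is not broken down here. In this assay compound 3 gives 36000 nM, a number within the scatter of compound 1 and beyond it only against compound 2.

Compound 4 `CC(=O)Nc1ccc2oc(-c3cccc(C(F)(F)F)c3)c(O)c(=O)c2c1` has not yet been measured. It stands to compound 3 as compound 2 stands to compound 1, through (trifluoromethyl in place of fluoro on an aromatic carbon). This is the same kind of change, not the same one: in compound 4 the entering group sits meta to a large group, whereas in compound 2 it sits para to a large group.

Going by the values given here, the expectation for compound 4 rests on compound 1 and compound 2, because a 2.2-fold lower number from compound 1 to compound 2 (0.34 log units; beyond the scatter) is the only measured instance of this kind of change. The expected step is a 2.0-fold lower number from compound 3 to compound 4 (0.30 log units; within the scatter). Compound 4 is therefore estimated at 18000 nM, with a range from 9000 nM to 36000 nM.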

Compound 4, half-maximal inhibitory concentration: 1000 nM
Beside the measured number, compound 4's estimate is 18-fold (1.26 log units) above it, and the stated range ends above it.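

In this assay, trifluoromethyl in place of fluoro gives a 36-fold lower number from compound 3 to compound 4 (1.56 log units; beyond the scatter), and the size of the step did not carry over from one core to the other: the same change on two cores in this assay, a 2.2-fold lower number (0.34 log units; beyond the scatter) from compound 1 to compound 2 and a 36-fold lower number (1.56 log units; beyond the scatter) from compound 3 to compound 4, 16-fold (1.21 log units) apart, beyond the scatter of two such steps The direction of the step is the same in both pairs, but two pairs are too few to make this a rule for the series. The comparison does not show that the core alone sets the size of the step, since in compound 4 the trifluoromethyl sits meta to a large group and not where it sits in compound 2, so core and place differ together.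

The compounds shown leave open what the step would be with the trifluoromethyl on the core of compound 3 in the place it holds in compound 2. They also leave open whether other groups in the place it holds in compound 4, such as chloro, nitrile or methoxy, would give a step of similar size.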